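Removing the Hydroxybutyl Chain: What to Expect for Compound 3

The source may hold more compounds than are shown below. What is called first, only, known or untested is meant among the compounds shown, and "the series" means these compounds.

Measured compounds:
compound 1, `CCOC(=O)c1cnn(C)c1NC(=O)NCc1ccccc1`: 18 nM
compound 2, `CCOC(=O)c1cnn(CC(O)CC)c1NC(=O)NC(C)C`: > 10 nM

Of the compounds shown here, two have been measured in a functional assay on cells (Neutrophil, Homo sapiens) for inhibition, with a stated time of 10 min; on this read-out lower numbers stand for stronger inhibition and higher numbers for weaker inhibition. Compound 1, which carries a benzyl group on the urea and a methyl on the ring nitrogen, gives 18 nM in this assay. For compound 2 only a limit is known. In this assay compound 2 gives > 10 nM, which is a limit of the assay and not a number. Where compound 2 stands relative to compound 1 can therefore not be told, as the evidence consists of the limit of > 10 nM in this assay, at which 1 of the 2 values shown sits.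

Compound 3, `CCOC(=O)c1cnn(C)c1NC(=O)NC(C)C`, has not yet been measured in this assay. It arises from compound 2 by hydrogen in place of 1-hydroxypropyl on a saturated chain carbon bound to an aromatic nitrogen. For the measured compounds named here, no pair of measured compounds shares this change, so the data give no measured step of this kind. Compound 3 shares the methyl on the ring nitrogen with compound 1 and the isopropyl urea with compound 2. The step from compound 2 to compound 3 is expected to be a step that the limit leaves unreadable from compound 2 to compound 3, a modest move that may not exceed the scatter. Compound 3 is therefore expected to give 30 nM, within a range from 8 nM to 120 nM.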

Compound 3, half-maximal inhibitory concentration: 77 nM
For compound 3 the middle estimate is 2.6-fold (0.41 log units) below the measured one, and the stated range covers the measured number.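

For the compounds shown here, the result gives the first readable step in this assay, a 4.3-fold higher number from compound 1 to compound 3 (0.63 log units; beyond the scatter), and this step belongs to isopropyl in place of benzyl on an amide-type nitrogen, the one place in which these two compounds differ, with the methyl on the ring nitrogen shared. For compound 2 the value is > 10 nM, which is a limit of the assay and not a number. The change from 2-hydroxybutyl to methyl on the ring nitrogen, the one place in which the other pair differs, therefore cannot be read as a step, although the isopropyl urea now has a measured number in compound 3: the limit of > 10 nM in this assay, at which 1 of the 3 values shown sits.

From the compounds shown here alone, whether the exchange of benzyl for isopropyl gives a step of like size with 2-hydroxybutyl on the ring nitrogen stays open, as does the size of the step from 2-hydroxybutyl to methyl itself. Also open, going by these compounds, is how a longer chain, an amine or a carboxylic acid would read in this assay if it took the place of the isopropyl on the amide-type nitrogen.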